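Replacing the vinyl end of compound 2 with an ethylsulfanyl chain

The source may report more compounds than this note shows. Statements on the series, on what has been measured and on what is new or still open speak of the compounds shown alone.

Of the compounds shown here, two have been tested in a functional assay on the whole organism with Rattus norvegicus as the target; on this read-out higher numbers stand for an effect only at larger amounts of compound and lower numbers for an effect already at smaller amounts. Compound 1, `CCCc1ccc2nc(N)sc2c1`, gives 6 mg/kg in this assay. Compound 2, `C=CCn1c(=N)sc2cc(OC(F)(F)F)ccc21`, gives 7 mg/kg in this assay, a value that lies within the usual scatter of that of compound 1, so the two cannot be told apart on these numbers. Compound 3, `CCSCCn1c(=N)sc2cc(OC(F)(F)F)ccc21`, has not yet been measured. It differs from compound 2 in a single place: (ethylsulfanyl)methyl in place of vinyl on a saturated chain carbon bound to an aromatic nitrogen. Cut one bond further out, the same difference reads allyl to 2-(ethylsulfanyl)ethyl. Among the compounds with values here, no measured pair in this set shows what such a change does, so there is no step to lean on. The expectation is that the step of no change at the digits printed from compound 2 to compound 3 (within the scatter) stays within the scatter, with no clear direction. On that basis compound 3 is estimated at 7 mg/kg, expected to fall between 3 mg/kg and 16 mg/kg.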

Compound 3, dose for half-maximal effect: 2.2 mg/kg
Beside the measured number, compound 3's estimate is 3.2-fold (0.50 log units) above it; the whole stated range lies above it.
By their numbers in this assay, from the lowest: compound 3; then compounds 1 and 2 (each within the scatter of the next).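

In this assay, within the data shown here, the chain on the aromatic nitrogen proves not to be indifferent, since the number falls a 3.2-fold lower number from compound 2 to compound 3 (0.50 log units; beyond the scatter) and this is the first step in the set to lie beyond the scatter. Among these compounds, at this position, therefore, (ethylsulfanyl)methyl in place of vinyl is not merely tolerated but goes with an effect at smaller amounts of compound, although the single step cannot separate the loss of the double bond from the gain of the longer, sulfur-bearing end. Nothing measured alongside these numbers speaks to why the value moved.

Open, as far as these compounds go, is whether the sulfur matters or the chain length alone, which an ether oxygen in its place or a plain pentyl chain would address. Also open, from the compounds shown here alone, is how the position responds to a still longer chain or a terminal amine.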